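Thiophene for furan on the shared core

A few compounds are considered here, and "the series" means these few. Any claim that something is new, unique, unknown or untested is made for them only; others in the source may bear on it.

In an assay on CHO cells for displacement of a labelled ligand from adenosine receptor A1 (Homo sapiens), read by scintillation counting, with a stated time of 120 min, tested at 1 uM (on this read-out lower numbers stand for less inhibition and higher numbers for more inhibition at the one concentration tested (going by the name of the read-out)), compound 1 `COc1ccc(-c2nc(N)c3nn(-c4ccccc4)cc3n2)cc1` gives 33%. Within the data shown here, compound 2 `COc1ccc(-c2nc(NC(=O)c3ccccc3)c3nn(-c4ccccc4)cc3n2)cc1` gives 2% in this assay, and a number 31 percentage points lower from compound 1 to compound 2 (beyond the scatter) is the only step measured in one place; it concerns a benzoyl in place of hydrogen on a nitrogen on an aromatic ring, not the group examined here. Compound 3 `O=c1[nH]c(-c2ccco2)nc2cn(-c3ccccc3)nc12` gives 1% in this assay, the lowest number shown, though within the scatter of compound 2 and beyond the scatter from compound 1. Compound 4 `O=c1[nH]c(-c2cccs2)nc2cn(-c3ccccc3)nc12` differs from compound 3 in thiophen-2-yl in place of furan-2-yl on an aromatic carbon. Among the measured compounds shown here, no measured step bears on this change, so no step beyond the scatter is expected in this assay: a number 2 percentage points higher from compound 3 to compound 4 (within the scatter) is the expected step. Compound 4 is estimated at 3%, within -8% to 15%.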

Compound 4, a percentage reported as inhibition, at one concentration (the size of the read-out at that concentration, not a potency): 6%
The estimate for compound 4 lay 3 percentage points below the measured number; low and high end bracket the measured number.
By their numbers in this assay, from the lowest: compounds 3, 2 and 4 (each within the scatter of the next); then compound 1.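

Thiophen-2-yl in place of furan-2-yl on the aromatic carbon between two ring nitrogen atoms gives a number 5 percentage points higher from compound 3 to compound 4 (within the scatter) in this assay and is the first step read at this position. Exchanging one five-membered aromatic ring for the other, oxygen for sulfur, therefore does not separate the two compounds on this read-out. Nothing measured here offers an explanation for this result.

Still open, as far as these compounds go, is whether an amine or a longer alkyl chain on this aromatic carbon of the same core would give a step beyond the scatter.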